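The source may report more compounds than this note shows. Statements on the series, on what has been measured and on what is new or still open speak of the compounds shown alone.

Measured compounds:
- compound 1 `O=C(NCc1ccc(S(=O)(=O)N2CCCCC2)cc1)c1cc2cnccc2s1`: 15%
- compound 2 `O=C(NCc1ccc(S(=O)(=O)c2ccccc2)cc1)c1c[nH]c2ccncc12`: > 99% (a limit)

For the measured compounds named here, in an ADME assay on microsomes from liver (Homo sapiens) for metabolic stability, read by LC-MS, with a stated time of 30 min, tested at 1 uM (a lower number here means that less of the compound is left, a higher number that more of the compound is left), compound 1 gives 15%, the only exact number so far. Compound 2 reads > 99%, which is a limit of the assay. Compound 3 `O=C(NCc1ccc(S(=O)(=O)N2CCCCC2)cc1)c1cc2cccnc2s1` has the same atoms as compound 1, joined differently: a group of 9 heavy atoms (7 carbon, 1 nitrogen, 1 sulfur; one five-membered aromatic ring with 1 hetero atom, one six-membered aromatic ring with 1 hetero atom) in place of a group of 9 heavy atoms (7 carbon, 1 nitrogen, 1 sulfur; one five-membered aromatic ring with 1 hetero atom, one six-membered aromatic ring with 1 hetero atom), on a carbonyl carbon. This exchange sits on a carbonyl carbon. Going by the values given here, no step between compounds differing in one place has been measured, so only a small upward shift, within the usual scatter, is expected: a number 7 percentage points higher from compound 1 to compound 3 (within the scatter). For compound 3 the estimated value is 22%, with an expected range of 8% to 50%.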

Compound 3, percent of the compound remaining: "below limit of detection" (no number reported)
Compound 3: no number reported; no gap can be computed for the estimate.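

For the compounds shown here, compound 3 has no reported number, so no step from compound 1 to compound 3 can be read. The compounds shown leave open how moving between these two ring groups on the carbonyl carbon shifts the percent of compound remaining. Nothing shown accounts for this result.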